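Furan-3-yl in Place of Iodo on a Ribonucleoside Core

The compounds below may be only part of what the source reports. "The series", "measured", "known", "first", "only" and "open" are said of these compounds alone.

Compound 1 `Nc1nc(N)c2c(-c3ccsc3)cn([C@@H]3O[C@H](CO)[C@@H](O)[C@H]3O)c2n1` gives > 20000 nM in a functional assay on HepG2 cells (Homo sapiens) for antiproliferative activity, read by XTT assay, with a stated time of 72 h; on this read-out lower numbers stand for stronger inhibition and higher numbers for weaker inhibition.
Compound 2 `Nc1nc(N)c2c(-c3cc4ccccc4o3)cn([C@@H]3O[C@H](CO)[C@@H](O)[C@H]3O)c2n1` gives > 20000 nM.
Compound 3 `COc1ncnc2c1c(I)cn2[C@@H]1O[C@H](CO)[C@@H](O)[C@H]1O` gives > 20000 nM.

Each of these three values is a limit of this assay rather than a number, and compound 3 therefore stands exactly where the two others stand, at the limit of > 20000 nM in this assay, at which 3 of the 3 values shown sit. Compound 4 `COc1ncnc2c1c(-c1ccoc1)cn2[C@@H]1O[C@H](CO)[C@@H](O)[C@H]1O` differs from compound 3 by one change: furan-3-yl in place of iodo on an aromatic carbon. Going by the values given here, the only measured step that swaps an aromatic group on the core is a step that the two limits leave unreadable from compound 1 to compound 2, in which both compounds remain at the limit, so that step yields neither a size nor a direction. Among the compounds with values here, no compound here that carries a five-membered aromatic ring with one hetero atom on the core reaches a number; compound 1 with thiophen-3-yl and compound 2 with 1-benzofuran-2-yl both stay at the limit. Compound 4 is therefore expected to remain at or near the limit, with a step that the limit leaves unreadable from compound 3 to compound 4 that is not larger than the scatter. The estimate for compound 4 is 25000 nM, between 10000 nM and 60000 nM, with a high chance that this assay again reports only a limit.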

Compound 4, half-maximal inhibitory concentration: 290 nM
For compound 4 the middle estimate is 86-fold (1.94 log units) above the measured one; the whole stated range lies above it.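

In this assay, going by these compounds alone, the change at this aromatic carbon, two ring bonds from the ring nitrogen, gives an at least 68-fold lower number from compound 3 to compound 4 (1.83 log units; beyond the scatter), the only step in the set whose size can be read. Compound 4 is the only compound shown that gives a number rather than a limit: the limit of > 20000 nM in this assay, at which 3 of the 4 values shown sit. Compound 1 and compound 2 also carry an aromatic group on this carbon and each remains at a limit, so such a group does not give a number on every core shown.

The compounds shown leave open whether the ring oxygen of furan-3-yl matters, since thiophen-3-yl appears here only on the core of compound 1. They also leave open whether an amine or a short alkyl chain on this carbon of the core of compound 4 would give a comparable number.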